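Swapping the Furan of Compound 2 for 3-Chlorophenyl

A few compounds are considered here, and "the series" means these few. Any claim that something is new, unique, unknown or untested is made for them only; others in the source may bear on it.

In a functional assay on HCT-116 cells (Homo sapiens) for antiproliferative activity, read by MTT assay, with a stated time of 24 h (a lower number here means a stronger inhibitor, a higher number a weaker inhibitor), compound 2 `COc1ccc(C(=O)/C=C/c2ccco2)c2c1C=CC(C)(C)O2` gives > 10000 nM, which is a limit of the assay and not a number. Compound 2 therefore stands at the limit of > 10000 nM in this assay, at which 1 of the 2 values shown sits. In this assay, compound 1 `COc1ccc(C(=O)/C=C/c2ccc(N(C)C)cc2)c2c1C=CC(C)(C)O2` gives 1920 nM. For the measured compounds named here, the only measured step, an at least 5.2-fold higher number from compound 1 to compound 2 (0.71 log units; beyond the scatter), lies beyond the scatter, and it replaces 4-(dimethylamino)phenyl with furan-2-yl.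

Compound 3 `COc1ccc(C(=O)/C=C/c2cccc(Cl)c2)c2c1C=CC(C)(C)O2` differs from compound 2 as follows: 3-chlorophenyl in place of furan-2-yl on a double-bonded chain carbon bound to a double-bonded chain carbon. This puts a six-membered aromatic ring of carbon only back on the chain, as in compound 1, though with a different group on it. Going by an at least 5.2-fold higher number from compound 1 to compound 2 (0.71 log units; beyond the scatter), a move toward a lower number seems likely, but this single step is only a rough guide. The expected change is an at least 2.2-fold lower number from compound 2 to compound 3 (0.34 log units; beyond the scatter), and it may prove modest. For compound 3, the estimated value is 4500 nM, with an expected range of 1500 nM to 12000 nM.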

Compound 3, half-maximal inhibitory concentration: > 10000 nM
Compound 3 gave a limit, no number; the forecaster's own chance of this, stated with the estimate: 30%; at least 2.2-fold (0.34 log units) between middle value and limit.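

Putting a six-membered aromatic ring of carbon only back on the chain is not enough on its own to bring a readable value back in this assay: with 3-chlorophenyl in place of 4-(dimethylamino)phenyl there is an at least 5.2-fold higher number from compound 1 to compound 3 (0.71 log units; beyond the scatter). The loss seen earlier with furan-2-yl therefore cannot be pinned on the ring type alone, as the group on the ring, or its place, also counts here. The step between the furan-2-yl and 3-chlorophenyl compounds cannot be read, as both values are limits, so neither can be ranked over the other: the limit of > 10000 nM in this assay, at which 2 of the 3 values shown sit.

Going by these compounds, whether the dimethylamino group itself or its place on the ring matters more remains open. A 3-(dimethylamino)phenyl or a 4-chlorophenyl group on the same chain would help separate the two, and a plain phenyl would show what the bare ring gives.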